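Sulfonyl for sulfanyl: expectation for compound 4

The source may hold more compounds than are shown below. What is called first, only, known or untested is meant among the compounds shown, and "the series" means these compounds.

In a functional assay on DU-145 cells (Homo sapiens) for inhibition, read by trypan blue exclusion, with a stated time of 96 h (a higher number here means a weaker inhibitor of growth, a lower number a stronger inhibitor of growth), compound 3 `O=C(/C(=C\c1c(O)cc(O)cc1O)Sc1ccc(Br)cc1)c1ccc(Cl)cc1` gives 50000 nM and stands level with compound 1 `Cc1ccc(S(=O)(=O)/C(=C/c2ccc(C)s2)C(=O)c2ccc(Cl)cc2)cc1` at 50000 nM as the highest number of the three, while compound 2 `Cc1ccc(S(=O)(=O)/C(=C/c2ccc(Cl)cc2)C(=O)c2ccc(Cl)cc2)cc1` gives 1000 nM in the same read-out.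

Compound 4 `Cc1ccc(S(=O)(=O)/C(=C/c2c(O)cc(O)cc2O)C(=O)c2ccc(Cl)cc2)cc1` has (4-methylphenyl)sulfonyl in place of (4-bromophenyl)sulfanyl on a double-bonded chain carbon bound to a carbonyl carbon and a double-bonded chain carbon. The change is counted as (4-methylphenyl)sulfonyl in place of (4-bromophenyl)sulfanyl on a double-bonded chain carbon bound to a carbonyl carbon and a double-bonded chain carbon and leaves the rest of compound 3 untouched.

Going by the values given here, no measured step covers this swap. Among the compounds with values here, the only measured step is a 50-fold lower number from compound 1 to compound 2 (1.70 log units; beyond the scatter) for 4-chlorophenyl in place of 5-methylthiophen-2-yl, a large step at another place, and both of its compounds already carry the (4-methylphenyl)sulfonyl group. It bears on compound 4 only indirectly. With that group, compound 2 reaches 1000 nM and compound 1 stays at 50000 nM so the group alone fixes no level, and a moderate drop is the most that can be expected.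

The step expected in this assay is a 10-fold lower number from compound 3 to compound 4 (1.00 log units; beyond the scatter) as an estimate, with no change also within reach. Compound 4 is estimated at 5000 nM with an expected range of 800 nM to 50000 nM for growth inhibition.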

Compound 4, concentration for 50% growth inhibition: > 100000 nM
Compound 4: a limit, no number; the forecaster's own chance of this, stated with the estimate: 10%; middle value at least 20-fold (1.30 log units) from the limit.
By their numbers in this assay, from the lowest: compound 2; then compounds 1 and 3 (each within the scatter of the next). At a limit, above all of these: compound 4.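

In this assay compound 4 stands at a limit of the assay and not at a number: the limit of > 100000 nM in this assay, at which 1 of the 4 values shown sits.

On a double-bonded chain carbon bound to a carbonyl carbon and a double-bonded chain carbon, (4-methylphenyl)sulfonyl in place of (4-bromophenyl)sulfanyl gives an at least 2.0-fold higher number from compound 3 to compound 4 (0.30 log units; that floor lies within the scatter), so with 2,4,6-trihydroxyphenyl in the molecule the swap brings no gain in growth inhibition, though its floor alone establishes no loss. With (4-methylphenyl)sulfonyl held fixed, 2,4,6-trihydroxyphenyl in place of 4-chlorophenyl gives an at least 100-fold higher number from compound 2 to compound 4 (2.00 log units; beyond the scatter), while 2,4,6-trihydroxyphenyl in place of 5-methylthiophen-2-yl gives an at least 2.0-fold higher number from compound 1 to compound 4 (0.30 log units; that floor lies within the scatter), so among the sulfonyl compounds only compound 2 is separated from compound 4 by a step beyond the scatter.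

Going by these compounds, the true size of the sulfonyl-for-sulfanyl step stays open, since only its floor can be read. Also open, on these data alone, are whether that swap reads the same with 4-chlorophenyl on the double-bonded chain carbon, and what a 4-aminophenyl group would give in place of 2,4,6-trihydroxyphenyl.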